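Hexyloxy for hexylsulfanyl in a well-tolerated series

This account rests on a few compounds, and the source may have more. Where it says the series, first, only, none or still open, it means among the compounds named here.

In an ADME assay on HFF cells (Homo sapiens) for cytotoxicity, with a stated time of 8 days (a higher number here means that more compound is tolerated, a lower number that less compound is tolerated), compound 1 (`CC(C)CSc1nc(N)nc2c1ncn2/C=C1/CC1(CO)CO`) gives > 300000 nM, which is a limit. Compound 2 (`CC(C)CNc1nc(N)nc2c1ncn2/C=C1/CC1(CO)CO`) gives > 300000 nM, also a limit. Compound 3 (`CCCCCCSc1nc(N)nc2c1ncn2/C=C1/CC1(CO)CO`) gives > 300000 nM, again only a limit and not a number. All three share one result: the limit of > 300000 nM in this assay, at which 3 of the 3 values shown sit. The measured steps are a step that the two limits leave unreadable from compound 1 to compound 2 and a step that the two limits leave unreadable from compound 1 to compound 3. Compound 4 (`CCCCCCOc1nc(N)nc2c1ncn2/C=C1/CC1(CO)CO`) carries hexyloxy in place of hexylsulfanyl on an aromatic carbon. The closest guide, a step that the two limits leave unreadable from compound 2 to compound 3, also swaps the group on that aromatic carbon, yet it offers no size to carry over. The expected result is a number no higher from compound 3 to compound 4 (the limit leaves the size open), with no change expected beyond the scatter. Compound 4 is estimated at 300000 nM, with an expected range of 150000 nM to 600000 nM.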

Compound 4, half-maximal cytotoxic concentration: > 200000 nM
Compound 4: a limit, no number; the forecaster's own chance of this, stated with the estimate: 85%; the middle value lies beyond the limit too.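

Compound 4, like compound 1, compound 2 and compound 3, gives only a limit and not a number, so no step among these four compounds can be read. Going by these compounds, the concentration at which any of them becomes toxic to the cells remains open.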